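Sulfonamide removal on the fused imidazolylamine core

The compounds below may be only part of what the source reports. "The series", "measured", "known", "first", "only" and "open" are said of these compounds alone.

Measured so far in a functional assay on Urethra with Alpha-1A adrenergic receptor (Oryctolagus cuniculus) as the target; a lower number here means a smaller maximal response, a higher number a larger maximal response:
compound 1 `CC(c1cccc(NS(C)(=O)=O)c1)c1c[nH]cn1`: 92%
compound 2 `CS(=O)(=O)Nc1ccc(O)c2c1CCCC2c1c[nH]cn1`: 34%
compound 3 `O=S(=O)(Nc1cccc2c1CCCC2c1c[nH]cn1)C1CC1`: 51%

Compound 3 stands second highest of the three numbers in this assay. Its nearest neighbour is compound 2, which gives 34%, a gap beyond the scatter; furthest away is compound 1, which gives 92%, also beyond the scatter. Within the data shown here, compounds 2 and 3 share the fused core, compound 1 carries the open-chain arrangement; no single-point step between any two measured compounds is available, so the values can only be compared as they are.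

Compound 4 `Nc1cccc2c1CCCC2c1c[nH]cn1` differs from compound 3 in one place: hydrogen in place of cyclopropylsulfonyl on a nitrogen on an aromatic ring. Every measured compound carries a sulfonyl group on that nitrogen, so nothing measured tells how this assay responds to its loss. The expectation is a downward step from compound 3 to compound 4 in this assay, of a size probably beyond the scatter, the step of a number 16 percentage points lower from compound 3 to compound 4 (beyond the scatter) being the estimate. For compound 4 the estimated maximal response is 35%, in a range from 15% to 65%.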

Compound 4, largest response reached (reported as efficacy), in percent of the reference or control that the assay uses: 84%
The estimate for compound 4 lay 49 percentage points below the measured number, and the stated range ends below it.
By their numbers in this assay, from the lowest: compound 2; then compound 3; then compounds 4 and 1 (each within the scatter of the next).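

Notes on the nitrogen on an aromatic ring: in this assay, hydrogen in place of cyclopropylsulfonyl gives a number 33 percentage points higher from compound 3 to compound 4 (beyond the scatter), the first single-place step available in the series. On this core, the sulfonyl group is therefore not needed for a large maximal response, since compound 4, with the plain amino group, gives 84%. Its removal raises the response rather than lowering it, but no measurement at hand accounts for the size or direction of this step.

The compounds shown leave open whether this rise follows from the loss of any sulfonyl group or is tied to cyclopropylsulfonyl in particular, and whether an acetyl group, a methyl group or a methylsulfonyl group on the same nitrogen would give a response nearer to that of compound 3 or that of compound 4. Also open, as far as these compounds go, is whether the same change carries over to the core of compound 1, and whether a hydroxyl group on the aromatic ring of compound 4 would alter the response.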